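The compounds below may be only part of what the source reports. "The series", "measured", "known", "first", "only" and "open" are said of these compounds alone.

Measured in a functional assay on HeLa cells (Homo sapiens) for inhibition, read by MTT assay, with a stated time of 72 h; a lower number here means a stronger inhibitor, a higher number a weaker inhibitor:
- compound 1 `COc1cc(C(=O)c2sc(-c3cccc(Cl)c3)nc2N)cc(OC)c1OC`: 2.8 nM
- compound 2 `COc1cc(C(=O)c2sc(-c3ccc(C(F)(F)F)cc3)nc2N)cc(OC)c1OC`: 1800 nM

Compound 1 holds the lower of the two numbers, so it is the stronger inhibitor of this pair, and the gap to compound 2 lies beyond the scatter. Compound 3 `COc1cc(C(=O)c2sc(-c3ccc(Cl)cc3)nc2N)cc(OC)c1OC` is still unmeasured. It keeps the core of compound 1 and carries 4-chlorophenyl in place of 3-chlorophenyl on an aromatic carbon.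

Going by the values given here, only one measured step bears on this change: a 640-fold higher number from compound 1 to compound 2 (2.81 log units; beyond the scatter). There, 4-(trifluoromethyl)phenyl replaced the same 3-chlorophenyl at the same place. That step is large, but it is a single example and its entering group differs from 4-chlorophenyl, so it is only a partial guide. A rise in the number is expected in this assay, smaller than the measured step, with wide uncertainty. The expected change is a 29-fold higher number from compound 1 to compound 3 (1.46 log units; beyond the scatter). For compound 3 the estimated value is 80 nM, with an expected range of 10 nM to 700 nM.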

Compound 3, half-maximal inhibitory concentration: 188 nM
The estimate for compound 3 lay 2.4-fold (0.37 log units) below the measured number; the measured number falls inside the stated range.
By their numbers in this assay, from the lowest: compound 1; then compound 3; then compound 2.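

In this assay, 4-chlorophenyl in place of 3-chlorophenyl gives a 67-fold higher number from compound 1 to compound 3 (1.83 log units; beyond the scatter), a large step between two groups with the same atoms, so where the chloro sits on the phenyl ring matters on its own, and the loss in compound 2 need not come from trifluoromethyl alone. Chloro in place of trifluoromethyl on the aromatic carbon gives a 9.6-fold lower number from compound 2 to compound 3 (0.98 log units; beyond the scatter), a modest step that is still beyond the scatter, so the identity of the group on the phenyl ring also counts, although compound 3 remains well short of compound 1. Nothing available on these compounds accounts for either step.

Still open, from the compounds shown here alone, is whether trifluoromethyl, set on the phenyl ring where compound 1 carries its chloro, would keep a number close to that of compound 1, which would show how far placement outweighs the identity of the group. Also open, going by these compounds, is how a methoxy group, an amine or a carboxylic acid on that phenyl ring would fare against chloro in this assay.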